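A cyclopentyl group gives way on compound 1

The compounds below may be only part of what the source reports. "The series", "measured", "known", "first", "only" and "open" are said of these compounds alone.

- compound 1 `O=C(C1CCCC1)N1N=CCC1c1ccccc1` gives 5.4
- compound 2 `CC(C)(C)C(=O)N1N=CCC1c1cccnc1` gives 3.2

In a physicochemical assay for lipophilicity, read by HPLC, measured as chromatographic lipophilicity, at pH 7.4 (on this read-out higher numbers stand for higher lipophilicity and lower numbers for lower lipophilicity), compound 1 stands highest of the two measured compounds (5.4) and compound 2 gives 3.2 in the same read-out, a gap that lies beyond the scatter. Among the compounds with values here, no two measured compounds differ in one place only, so no measured step guides what follows.

Compound 3 `CC(C)(CN)C(=O)N1N=CCC1c1ccccc1` has not yet been measured. Within the data shown here, it keeps the core of compound 1 and carries 1-(aminomethyl)-1-methylethyl in place of cyclopentyl on a carbonyl carbon as its only change. The entering group has nitrogen, a hydrogen-bond donor and no ring, while the leaving group is a ring of carbon only. A large fall in this assay is therefore expected, far beyond the scatter. The expected step is a number 3.20 log units lower from compound 1 to compound 3 (beyond the scatter) as an estimate. For compound 3 the estimated value is 2.2 with an expected range from 1.3 to 3.2 once it is measured.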

Compound 3, distribution coefficient: 1.4
Compound 3: the middle estimate sits 0.80 log units above what was measured; the range from low to high includes it.
By their numbers in this assay, from the lowest: compound 3; then compound 2; then compound 1.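

At the position on a carbonyl carbon, this assay proves highly sensitive to the group carried there: with 1-(aminomethyl)-1-methylethyl in place of cyclopentyl, the read-out shows a number 4.00 log units lower from compound 1 to compound 3 (beyond the scatter) in one change to the core of compound 1. The heavy-atom count of the group stays the same, so this large step comes with a change in its make-up, from a ring of carbon only to an open group with nitrogen, a hydrogen-bond donor and a hydrogen-bond acceptor. Nothing in the data accounts for the size of this step.

The change removes the ring and brings in the nitrogen together, and the compounds shown do not separate the two. A hydroxyl in place of the amine, or an aminocyclopentyl group that keeps the ring, would bear on that question.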